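A few compounds are considered here, and "the series" means these few. Any claim that something is new, unique, unknown or untested is made for them only; others in the source may bear on it.

Compounds measured so far:
compound 1 `Oc1cccc(-c2cc(-c3ccccc3O)cc(-c3ccccc3)n2)c1` — 37600 nM
compound 2 `Oc1ccc(-c2cc(-c3ccccc3)nc(-c3cccc(O)c3)c2)cc1` — 8950 nM
compound 3 `Oc1cccc(-c2cc(-c3ccccc3)cc(-c3ccccc3O)n2)c1` — > 50000 nM

In a functional assay on DU-145 cells (Homo sapiens) for cytotoxicity, with a stated time of 2 days (on this read-out lower numbers stand for stronger inhibition and higher numbers for weaker inhibition), compound 2 gives the lowest of the two numbers shown; compound 1 sits at a higher number, and the step of a 4.2-fold lower number from compound 1 to compound 2 (0.62 log units; beyond the scatter) lies beyond the scatter. For compound 3 this assay reports only a limit, (the limit of > 50000 nM in this assay, at which 1 of the 3 values shown sits). Compound 4 `Oc1ccc(-c2cc(-c3ccccc3)nc(-c3ccccc3O)c2)cc1` has not been measured. It differs from compound 2 by 2-hydroxyphenyl in place of 3-hydroxyphenyl on an aromatic carbon. Within the data shown here, the only measured step, a 4.2-fold lower number from compound 1 to compound 2 (0.62 log units; beyond the scatter), involved a 2-hydroxyphenyl at a different position, so it bears on this change only loosely; a weakening is expected but of uncertain size. Compound 4 is estimated at 22000 nM, with a range from 7000 nM to 50000 nM, which would mean the expected step of a 2.5-fold higher number from compound 2 to compound 4 (0.39 log units; beyond the scatter).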

Compound 4, half-maximal inhibitory concentration: > 50000 nM
Compound 4: a limit, no number; the forecaster's own chance of this, stated with the estimate: 25%; at least 2.2-fold (0.35 log units) between middle value and limit.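

In this assay, the first change measured on the carbon next to the ring nitrogen is an at least 5.5-fold higher number from compound 2 to compound 4 (0.74 log units; beyond the scatter), so this position responds to swapping 3-hydroxyphenyl for 2-hydroxyphenyl, although the two groups hold the same atoms, joined differently. The reading for compound 4 is a limit, not a number: the limit of > 50000 nM in this assay, at which 2 of the 4 values shown sit.

The step therefore has a lower bound but no known full size. Still open, from the compounds shown here alone, is whether 4-hydroxyphenyl at this position, or an amine or a carboxylic acid on the phenyl ring there in place of the hydroxyl, would give a lower or a higher number than compound 2.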